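This account rests on a few compounds, and the source may have more. Where it says the series, first, only, none or still open, it means among the compounds named here.

In an in vitro ADME assay on microsomes from liver (Rattus norvegicus) for metabolic stability, tested at 2 uM (on this read-out higher numbers stand for a longer-lived compound and lower numbers for a shorter-lived compound), compound 1 `CC(C)(O)C#Cc1ccc(NC(=O)CSc2nnnn2-c2ccc(C3CC3)cc2Cl)c(Cl)c1` gives 1.4 h and compound 2 `CC(C)(C#Cc1ccc(NC(=O)CSc2nnnn2-c2ccc(C3CC3)cc2Cl)c(Cl)c1)CNCC(=O)O` gives 1.32 h, so compound 1 stands level with compound 2, within the scatter. Compound 3 `CC(C)(C#Cc1ccc(NC(=O)CSc2nnnn2-c2ccc(C3CC3)cc2Cl)c(Cl)c1)C(=O)O` carries carboxy in place of hydroxy on a saturated chain carbon bound to two saturated chain carbons and a triple-bonded carbon. Going by the values given here, the one measured change on that carbon, a 1.1-fold lower number from compound 1 to compound 2 (0.03 log units; within the scatter), is a single precedent, so no step beyond the scatter is expected in this assay. The estimated step is a 1.1-fold lower number from compound 1 to compound 3 (0.03 log units; within the scatter). Compound 3 is expected at 1.3 h, with an estimated range of 0.7 h to 2.4 h.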

Compound 3, half-life: 1.5 h
Compound 3: middle estimate off by 1.2-fold (0.06 log units), on the low side; the measured number falls inside the stated range.
By their numbers in this assay, from the lowest: compounds 2, 1 and 3 (each within the scatter of the next).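

In this assay, a second replacement of hydroxy on this saturated chain carbon also stays within the scatter: carboxy gives a 1.1-fold higher number from compound 1 to compound 3 (0.03 log units; within the scatter), and against the longer group it gives a 1.1-fold higher number from compound 2 to compound 3 (0.06 log units; within the scatter). Going by these compounds alone, all three groups on this carbon therefore read level, with no compound going against that. Nothing available explains this flat read-out.

On these data alone, whether a plain methyl or an aminomethyl on the same carbon would also stay level remains open. The same holds for a longer chain ending in a carboxylic acid.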